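This account rests on a few compounds, and the source may have more. Where it says the series, first, only, none or still open, it means among the compounds named here.

In an ADME assay on THP-1 cells (Homo sapiens) for cytotoxicity, read by resazurin assay, with a stated time of 48 h (a lower number here means a stronger inhibitor, a higher number a weaker inhibitor), compound 1 `N#Cc1ccccc1-c1ccc(Cn2cccc(O)c2=S)cc1` gives > 10 ug/mL as a limit of the assay. Compound 2 `CN(C)c1ccc(-c2ccc(Cn3cccc(O)c3=S)cc2)cc1` gives > 10 ug/mL as a limit too. Compound 3 `O=c1c(O)cccn1Cc1cn(-c2ccccc2)nn1` likewise gives only a limit and no number, > 10 ug/mL in the same read-out. All three stand at the limit of > 10 ug/mL in this assay, at which 3 of the 3 values shown sit, and so have no order among them. Compound 4 `CN(C)c1ccc(-n2cc(Cn3cccc(O)c3=O)nn2)cc1` differs from compound 3 in one place: dimethylamino in place of hydrogen on an aromatic carbon with dimethylamino in place of hydrogen on an aromatic carbon. Among the measured compounds shown here, no measured pair shows this change. The step that the limit leaves unreadable from compound 3 to compound 4 is expected to stay within the scatter in this assay and to have no clear direction. Compound 4 is estimated at 15 ug/mL with an expected range from 6 ug/mL to 40 ug/mL and would probably again be reported as a limit.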

Compound 4, half-maximal inhibitory concentration: > 10 ug/mL
Compound 4 was reported as a limit (the forecaster's own chance of this, stated with the estimate: 80%); the middle value lies beyond the limit too.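

Compound 3 and compound 4 are both reported as limits, so no step can be read between them: the limit of > 10 ug/mL in this assay, at which 4 of the 4 values shown sit.

The compounds shown leave open whether dimethylamino in place of hydrogen changes this read-out at all.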